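The source may hold more compounds than are shown below. What is called first, only, known or untested is meant among the compounds shown, and "the series" means these compounds.

Compound 1 `Cn1c(-n2cccc2)c(C#N)c2c(N)ncnc21` and compound 2 `Cn1c(NCc2ccccc2F)c(C#N)c2c(N)ncnc21` share one core and were both tested in an assay on isolated protein for binding affinity to Leucine-rich repeat serine/threonine-protein kinase 2 (Homo sapiens), read by TR-FRET and LanthaScreen, with a stated time of 2 h; a lower number here means a stronger inhibitor, a higher number a weaker inhibitor. In this assay compound 1 gives 239 nM, and compound 2 gives 145 nM in this assay. The two numbers lie within the usual scatter of each other, so compound 1 stands alongside compound 2 rather than apart from it, and nothing beyond the scatter separates the pair.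

Compound 3 `C[C@@H]1CCCN1c1c(C#N)c2c(N)ncnc2n1C` has not yet been measured. It differs from compound 1 in one place: 2-methylpyrrolidin-1-yl in place of 1H-pyrrol-1-yl on an aromatic carbon. Among the measured compounds shown here, no step between measured compounds of this kind is available, so any expectation for compound 3 rests only on compound 1, compound 2 and the change itself. The change is expected to give a small step in this assay toward a lower number, one that may still sit inside the scatter, and the expected step of a 1.6-fold lower number from compound 1 to compound 3 (0.20 log units; within the scatter) is accordingly modest. Compound 3 is therefore expected to give about 150 nM in this assay, with a likely range from 50 nM to 450 nM.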

Compound 3, inhibition constant: 0.4 nM
Compound 3: middle estimate off by 380-fold (2.57 log units), on the high side; measured number outside the range, below it.
By their numbers in this assay, from the lowest: compound 3; then compounds 2 and 1 (each within the scatter of the next).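

Placing 2-methylpyrrolidin-1-yl instead of 1H-pyrrol-1-yl on this aromatic carbon, next to the ring atom that bears a cyano group and the ring atom that bears a methyl group, gives a 600-fold lower number from compound 1 to compound 3 (2.78 log units; beyond the scatter) in this assay, so the group at this position can move the number far beyond the scatter, which the values of compound 1 and compound 2 alone did not show. The change replaces a five-membered aromatic ring with a five-membered non-aromatic ring, adds one heavy atom and brings in a defined stereocentre, while the counts of hydrogen-bond donors and acceptors stay the same and neither group carries a net charge. Nothing in the data shown explains the size of this step.

The compounds shown leave open how the step divides among the methyl group, the loss of aromaticity and the defined stereocentre, a question that plain pyrrolidin-1-yl and the mirror-image 2-methylpyrrolidin-1-yl would address. They also leave open whether a six-membered piperidin-1-yl or an ethyl group in place of the methyl would keep a number close to that of compound 3.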